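The compounds below may be only part of what the source reports. "The series", "measured", "known", "first", "only" and "open" are said of these compounds alone.

Working notes on the series. Of the compounds shown here, three of one shared core have been measured in a functional assay on isolated protein for inhibition of Glucose-dependent insulinotropic receptor (Rattus norvegicus), read by HTRF and cAMP accumulation; a higher number here means that more compound is needed for the effect, a lower number that less compound is needed. Compound 1 `CCC1(OC(=O)N2CCC(Oc3ncnc(Oc4ccc(S(C)(=O)=O)nc4C)c3F)CC2)CC1` gives 333 nM, compound 2 `Cc1nc(S(C)(=O)=O)ccc1Oc1ncnc(OC2CCN(C(=O)OC3(C(F)(F)F)COC3)CC2)c1F` gives 342 nM, and compound 3 `Cc1nc(S(C)(=O)=O)ccc1Oc1ncnc(OC2CCN(C(=O)SC(C)C)CC2)c1F` gives 41.3 nM. Compound 3 stands lowest of the three, and its gap to each of the others is beyond the scatter. The steps into compound 3 were an 8.1-fold lower number from compound 1 to compound 3 (0.91 log units; beyond the scatter) and an 8.3-fold lower number from compound 2 to compound 3 (0.92 log units; beyond the scatter), while a 1.0-fold higher number from compound 1 to compound 2 (0.01 log units; within the scatter) showed that exchanging one oxygen-linked group for another at the carbonyl carbon left the number unchanged.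

Compound 4 `Cc1nc(S(C)(=O)=O)ccc1Oc1ncnc(OC2CCN(C(=S)OC3(C)CC3)CC2)c1F` has not been measured in this assay . Its change from compound 3 is a group of 7 heavy atoms (5 carbon, 1 oxygen, 1 sulfur; one three-membered non-aromatic ring of carbon only) in place of a group of 6 heavy atoms (4 carbon, 1 oxygen, 1 sulfur; no ring), on an amine nitrogen in a ring. This reverses the kind of step that produced the two modest gains into compound 3, since compound 4 again carries an oxygen-linked group with a three-membered ring, as compound 1 and compound 2 do in their own way, so a number above that of compound 3 is expected, of about a 3.1-fold higher number from compound 3 to compound 4 (0.50 log units; beyond the scatter). For compound 4 the estimate in this assay is 130 nM, with a range from 40 nM to 420 nM.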

Compound 4, half-maximal effective concentration: 48.8 nM
Estimate against measurement, compound 4: 2.7-fold (0.43 log units) above, and the stated range covers the measured number.
By their numbers in this assay, from the lowest: compounds 3 and 4 (each within the scatter of the next); then compounds 1 and 2 (each within the scatter of the next).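

In this assay, a 1.2-fold higher number from compound 3 to compound 4 (0.07 log units; within the scatter), so a three-membered ring in the group on the ring amine nitrogen does not by itself raise the number once sulfur is in that group. With a 6.8-fold lower number from compound 1 to compound 4 (0.83 log units; beyond the scatter) and a 7.0-fold lower number from compound 2 to compound 4 (0.85 log units; beyond the scatter), all four compounds now fall into two groups: those with sulfur in this group, compound 3 as a sulfanyl link and compound 4 as a thiocarbonyl, give the lower numbers, and none of the four goes against this. No measurement shown explains this split.

The compounds shown leave open whether the sulfur itself accounts for the split, as compound 4 differs from compound 1 in the alkyl part as well. An isopropylamino group on the carbonyl carbon would show whether a nitrogen link can stand in for the sulfur link.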